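From 4-hydroxyphenyl to 2-fluorophenyl on a shared core

The source may report more compounds than this note shows. Statements on the series, on what has been measured and on what is new or still open speak of the compounds shown alone.

- Compound 1 `N#Cc1ccc(-c2cc(Cl)cn3c([N+](=O)[O-])c(CS(=O)(=O)c4ccccc4)nc23)cc1` gives > 3900 nM in an ADME assay on HepG2 cells (Homo sapiens) for cytotoxicity, read by MTT assay, with a stated time of 72 h (on this read-out higher numbers stand for lower toxicity in this test and lower numbers for higher toxicity in this test), as a limit
- Compound 2 `O=[N+]([O-])c1c(CS(=O)(=O)c2ccccc2)nc2c(-c3ccc(O)cc3)cc(Cl)cn12` gives > 12500 nM in this assay as a limit

Both values are limits, so neither compound has an exact reading. Compound 2 stands at the limit of > 12500 nM in this assay, at which 1 of the 2 values shown sits, and has no exact number. Compound 3 `O=[N+]([O-])c1c(CS(=O)(=O)c2ccccc2)nc2c(-c3ccccc3F)cc(Cl)cn12` differs from it by one group, 2-fluorophenyl in place of 4-hydroxyphenyl on an aromatic carbon. Within the data shown here, the only measured step that bears on this change is a step that the two limits leave unreadable from compound 1 to compound 2, which swaps a group on the same aromatic ring and offers no size to carry over. No step beyond the usual scatter is therefore expected in this assay, and no direction can be named. The expected change is a step that the limit leaves unreadable from compound 2 to compound 3 as an estimate only. Compound 3 is expected at about 15000 nM, with an estimated range from 5000 nM to 50000 nM, and may again be reported only as a limit.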

Compound 3, half-maximal cytotoxic concentration: > 3900 nM
Compound 3 gave a limit, no number; the forecaster's own chance of this, stated with the estimate: 70%; the middle value is on the limit's open side.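

Among these compounds, compound 1, compound 2 and compound 3 all give only limits in this assay, so no step among them can be read. The compounds shown leave open where their exact values lie, and whether 4-cyanophenyl, 4-hydroxyphenyl or 2-fluorophenyl on the shared core makes any difference.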